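Fluorophenyl exchange in the shared core: clearance notes

The source may hold more compounds than are shown below. What is called first, only, known or untested is meant among the compounds shown, and "the series" means these compounds.

In an ADME assay on microsomes from liver (Mus musculus) for metabolic stability, read by LC-MS, using NADPH, with a stated time of 60 min, tested at 1 uM, in the presence of a further agent that is not named here (a higher number here means faster removal of the compound, a lower number slower removal), compound 1 `Clc1ccc2nc(-c3ccccn3)c(Nc3ccc4c(c3)OCCO4)n2c1` gives only a limit, > 1000 uL/min. Compound 3 `Cc1ccn2c(NC3CCCC3)c(-c3ccc(N(C)C)cc3)nc2c1` likewise returns a limit, > 1000 uL/min. Among the measured compounds shown here, compound 2 `COc1ccn2c(Nc3cc(F)cc(F)c3)c(-c3ccccn3)nc2c1` is the one compound with a number in this assay, 62 uL/min, and so stands apart from the limit of > 1000 uL/min in this assay, at which 2 of the 3 values shown sit. Compound 4 `COc1ccn2c(Nc3ccc(F)cc3)c(-c3ccccn3)nc2c1` differs from compound 2 by one change: 4-fluorophenyl in place of 3,5-difluorophenyl on a nitrogen on an aromatic ring. For the measured compounds named here, no measured step covers this exchange, so the expected step from compound 2 to compound 4 in this assay, a 1.5-fold higher number from compound 2 to compound 4 (0.16 log units; within the scatter), is taken as small, perhaps toward faster removal, but not clearly beyond the usual scatter. Compound 4 is therefore expected to give about 90 uL/min in this assay, within a range from 35 uL/min to 250 uL/min.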

Compound 4, intrinsic clearance in a liver preparation (reported as CLH), per the amount of preparation that the assay uses: 117 uL/min
Beside the measured number, compound 4's estimate is 1.3-fold (0.11 log units) below it; measured number inside the range.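

Among the compounds shown here, the exchange of 3,5-difluorophenyl for 4-fluorophenyl on a nitrogen on an aromatic ring gives the first measured step at this position in this assay: a 1.9-fold higher number from compound 2 to compound 4 (0.28 log units; within the scatter). The change in fluorine count on this ring therefore has no effect here that can be told from the scatter. Compound 4, like compound 2, gives a number and not a limit, and the two stand apart from the remaining compounds: the limit of > 1000 uL/min in this assay, at which 2 of the 4 values shown sit.

On these data alone, what a phenyl ring carrying a nitrile or a carboxylic acid would give at this nitrogen remains open. As far as these compounds go, whether the step holds on a different core is also open.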